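A few compounds are considered here, and "the series" means these few. Any claim that something is new, unique, unknown or untested is made for them only; others in the source may bear on it.

Compound 1 `Fc1ccc2c(c1)CCC(c1nnc(-c3cn(Cc4c(F)cccc4F)nn3)o1)O2`: 23100 nM
Compound 2 `Fc1ccc2c(c1)CCC(c1nnc(-c3ccccc3Cl)o1)O2`: 40800 nM

Both numbers come from a functional assay; a lower number here means a stronger inhibitor, a higher number a weaker inhibitor. Compound 2 stands at the top of this short list, but compound 1 lies within the scatter of it, so the two cannot be told apart. Compound 3 `Fc1ccc2c(c1)CCC(c1nnc(-c3cnccn3)o1)O2` differs from compound 2 in one place: pyrazin-2-yl in place of 2-chlorophenyl on an aromatic carbon. Among the measured compounds shown here, no pair of measured compounds shows what such a change does, so no step can be read from the data. Compound 3 is expected to stay close to compound 2, with an estimated step of a 1.2-fold lower number from compound 2 to compound 3 (0.07 log units; within the scatter), not beyond the scatter. The estimate for compound 3 is 35000 nM, between 10000 nM and 120000 nM.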

Compound 3, half-maximal inhibitory concentration: 73400 nM
Compound 3: middle estimate off by 2.1-fold (0.32 log units), on the low side; the measured number falls inside the stated range.
By their numbers in this assay, from the lowest: compounds 1, 2 and 3 (each within the scatter of the next, the first and the last beyond it).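

In this assay, putting pyrazin-2-yl in place of 2-chlorophenyl on this aromatic carbon gives a 1.8-fold higher number from compound 2 to compound 3 (0.26 log units; within the scatter), so the two compounds cannot be told apart. At this position, then, a ring of carbon only bearing chlorine and a ring with 2 hetero atoms and 2 hydrogen-bond acceptors read the same within the scatter. Nothing measured here explains this result.

From the compounds shown here alone, it remains open whether any group at this position can move the number beyond the scatter. An amine, a carboxylic acid or a plain phenyl ring could test this.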